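A few compounds are considered here, and "the series" means these few. Any claim that something is new, unique, unknown or untested is made for them only; others in the source may bear on it.

Series notes. The shared core carries an anilino group and an alkoxy chain ending in an amide to a sulfamoylphenyl group; the compounds differ only in the substituent on the anilino ring. In a functional assay on NCI-H1975 cells (Homo sapiens) for antiproliferative activity, read by MTT assay, with a stated time of 72 h (a higher number here means a weaker inhibitor, a lower number a stronger inhibitor), compound 1 `COc1cc2ncnc(Nc3ccc(F)cc3)c2cc1OCCCCC(=O)Nc1ccc(S(N)(=O)=O)cc1` gives only a limit, > 40000 nM; this is the limit of > 40000 nM in this assay, at which 1 of the 3 values shown sits. Compound 2 `COc1ccc(Nc2ncnc3cc(OC)c(OCCCCC(=O)Nc4ccc(S(N)(=O)=O)cc4)cc23)cc1OC` gives 9230 nM in this assay. Compound 3 `COc1cc2ncnc(Nc3ccc(C(F)(F)F)cc3)c2cc1OCCCCC(=O)Nc1ccc(S(N)(=O)=O)cc1` gives 12000 nM in this assay, the higher of the two numbers measured, but its distance from compound 2, a 1.3-fold higher number from compound 2 to compound 3 (0.11 log units; within the scatter), lies within the scatter, so no order between the two is claimed. Trifluoromethyl in place of fluoro gave an at least 3.3-fold lower number from compound 1 to compound 3 (0.52 log units; beyond the scatter), and 3,4-dimethoxyphenyl in place of 4-fluorophenyl gave an at least 4.3-fold lower number from compound 1 to compound 2 (0.63 log units; beyond the scatter).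

Compound 4 `COc1cc2ncnc(Nc3ccccc3)c2cc1OCCCCC(=O)Nc1ccc(S(N)(=O)=O)cc1` has not yet been measured. It differs from compound 3 by hydrogen in place of trifluoromethyl on an aromatic carbon. Going by the values given here, of the measured steps, only the one from compound 1 to compound 3 changes the group at this place, and it moved beyond the scatter; the step from compound 2 to compound 3 stayed within it. Removing the trifluoromethyl is therefore expected to raise the number, with an expected step of a 2.1-fold higher number from compound 3 to compound 4 (0.32 log units; beyond the scatter), and a return to a limit cannot be excluded. Compound 4 is estimated at 25000 nM, within a range from 8000 nM to 80000 nM.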

Compound 4, half-maximal inhibitory concentration: 14100 nM
Compound 4: middle estimate off by 1.8-fold (0.25 log units), on the high side; the measured number falls inside the stated range.
By their numbers in this assay, from the lowest: compounds 2, 3 and 4 (each within the scatter of the next). At a limit, above all of these: compound 1.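

In this assay, hydrogen in place of trifluoromethyl gives a 1.2-fold higher number from compound 3 to compound 4 (0.07 log units; within the scatter), and phenyl in place of 3,4-dimethoxyphenyl gives a 1.5-fold higher number from compound 2 to compound 4 (0.18 log units; within the scatter), so neither substituent separates from the bare phenyl ring, and these three anilino rings cannot be ordered. Going by these compounds alone, the only change at this place that reads beyond the scatter is hydrogen in place of fluoro, with an at least 2.8-fold lower number from compound 1 to compound 4 (0.45 log units; beyond the scatter), so the earlier impression that trifluoromethyl itself lowers the number does not hold; what sets the series apart is the fluoro compound, which goes against an otherwise flat picture. Compound 1 remains a limit, not a number: the limit of > 40000 nM in this assay, at which 1 of the 4 values shown sits.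

Still open, as far as these compounds go, is whether the result for fluoro is particular to that atom, which chloro or bromo at the same place would test, and whether an amine or a nitrile there would move the number beyond the scatter at all. Also open, from the compounds shown here alone, is how much the rest of the molecule contributes, as a longer chain or a carboxylic acid in place of the sulfamoyl group would show.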